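The compounds below may be only part of what the source reports. "The series", "measured", "known", "first", "only" and "open" are said of these compounds alone.

Measured so far:
- compound 1 `CN(C)C1(Cc2ccccc2)CCN(c2cc(C(F)(F)F)ccc2CNC(=O)Nc2ccc(CNS(N)(=O)=O)c(F)c2)CC1` — 120 nM
- compound 2 `CN(C)C1(Cc2ccccc2)CCN(c2cc(C(F)(F)F)ccc2CNC(=O)Nc2ccc3c(c2)OCC3)CC1` — 31.3 nM
- compound 3 `CN(C)C1(Cc2ccccc2)CCN(c2cc(C(F)(F)F)ccc2CNC(=O)Nc2cccc3[nH]c(=O)ccc23)CC1` — 30.6 nM

All three share one core and differ only in the aryl group on the urea nitrogen. In an assay on CHO cells for antagonist activity at transient receptor potential cation channel subfamily V member 1 (Homo sapiens), read by scintillation counting, with a stated time of 5 min, in the presence of a further agent that is not named here (on this read-out higher numbers stand for an effect only at larger amounts of compound and lower numbers for an effect already at smaller amounts), compound 3 gives 30.6 nM, the lowest number of the three, but the step between the two nearest compounds is a 1.0-fold lower number from compound 2 to compound 3 (0.01 log units; within the scatter), so compound 2 and compound 3 cannot be separated; only compound 1 stands apart, with a number beyond the scatter above both.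

Compound 4 `CN(C)C1(Cc2ccccc2)CCN(c2cc(C(F)(F)F)ccc2CNC(=O)Nc2cccc3ncccc23)CC1` is not yet measured. It differs from compound 3 by a group of 10 heavy atoms (9 carbon, 1 nitrogen; one six-membered aromatic ring of carbon only, one six-membered aromatic ring with 1 hetero atom) in place of a group of 11 heavy atoms (9 carbon, 1 nitrogen, 1 oxygen; one six-membered aromatic ring of carbon only, one six-membered aromatic ring with 1 hetero atom), on an amide-type nitrogen. Among the compounds with values here, none of the measured steps is the same change. Within the data shown here, the one measured step, a 1.0-fold lower number from compound 2 to compound 3 (0.01 log units; within the scatter), shows that a substantial reshaping of the aryl group on this nitrogen left the number essentially unchanged; compound 1 shows that some aryl groups do raise the number clearly. With only this to go on, a step of modest size is expected for a 1.5-fold higher number from compound 3 to compound 4 (0.17 log units; within the scatter), direction uncertain, likely inside or close to the scatter. Compound 4 is therefore estimated at 45 nM, with a range from 15 nM to 150 nM.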

Compound 4, half-maximal effective concentration: 32 nM
The estimate for compound 4 lay 1.4-fold (0.15 log units) above the measured number, within the range that was stated.
By their numbers in this assay, from the lowest: compounds 3, 2 and 4 (each within the scatter of the next); then compound 1.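

In this assay, putting quinolin-5-yl on the amide-type nitrogen in place of the group of compound 3 gives a 1.0-fold higher number from compound 3 to compound 4 (0.02 log units; within the scatter) and is read as no change. The leaving group has 1 hydrogen-bond donor and 1 double bond outside aromatic rings, the entering group has 0 donors and no such bond, and both have 1 hydrogen-bond acceptor, so in this pair neither feature is needed to keep the number at this level. Within the data shown here, with a 1.0-fold higher number from compound 2 to compound 4 (0.01 log units; within the scatter) also inside the scatter, three different aryl groups on this nitrogen now cannot be separated, which widens what the single earlier step showed. No data here account for this flat response.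

Open, from the compounds shown here alone, is how far this tolerance reaches: a plain phenyl group, or quinolin-5-yl carrying an amine or a carboxylic acid, could show whether the number stays at this level or moves clearly. Also open is whether any group on this nitrogen gives a number clearly below those of this cluster, since the compounds shown mark only a level shared by three groups.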